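The source may hold more compounds than are shown below. What is called first, only, known or untested is meant among the compounds shown, and "the series" means these compounds.

Measured so far:
Compound 1 `CCCc1ccc(NC(=O)N[C@H](C)c2ccccc2)cc1` — 33%
Compound 2 `CCCc1ccc(NC(=O)N[C@@H](C)c2ccccc2)cc1` — 97%
Compound 3 `COc1cccc(NC(=O)N[C@H](C)c2ccccc2)c1` — 104%

In an ADME assay on the whole organism with Oryza sativa as the target, tested at 0.1 uM (on this read-out lower numbers stand for a stronger effect and higher numbers for a weaker effect at the one concentration tested), compound 1 gives 33%, the lowest of the three numbers and therefore the strongest effect; compound 2 and compound 3 both sit far higher, beyond the scatter. Within the data shown here, the one step between directly comparable compounds is a number 64 percentage points higher from compound 1 to compound 2 (beyond the scatter), and it rests only on (the fact that compounds 1 and 2 differ only in the configuration as drawn), so the read-out is very sensitive to configuration as drawn.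

Compound 4 `C[C@@H](NC(=O)Nc1ccc(Br)cc1)c1ccccc1` is now to be measured in this assay. It keeps the stereocentre as drawn in compound 1 and differs by bromo in place of propyl on an aromatic carbon. Among the measured compounds shown here, no measured step addresses a change of the substituent on that ring: compound 3 carries methoxy in another place and differs from compound 1 in more than one way, so its value alone shows only that it is high. The step to compound 4 is therefore unanchored; a move away from the strong effect of compound 1 toward the rest of the series seems more likely than not, but with a wide range. Compound 4 is estimated at 55%, between 20% and 100%, meaning an expected step of a number 22 percentage points higher from compound 1 to compound 4 (beyond the scatter).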

Compound 4, a percentage reported as activity, at one concentration (the size of the read-out at that concentration, not a potency): 100%
Compound 4: middle estimate off by 45 percentage points, on the low side; low and high end bracket the measured number.
By their numbers in this assay, from the lowest: compound 1; then compounds 2, 4 and 3 (each within the scatter of the next).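

In this assay, the para position on this ring proves as decisive for the series as the stereocentre: with the stereocentre kept as drawn, bromo in place of propyl gives a number 67 percentage points higher from compound 1 to compound 4 (beyond the scatter). The low number of compound 1 therefore depends on the propyl group as well as on the configuration, and each of these two single changes from compound 1 leads to a number far above it. No measurement at hand bears on why this substituent change has so large a step.

As far as these compounds go, whether the low number needs propyl itself remains open, as a longer chain such as butyl, a shorter one such as ethyl, or an amine in the same place could either keep or lose it. Also open, from the compounds shown here alone, is how the configuration of compound 2 would behave with a substituent other than propyl on this ring.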